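The source may report more compounds than this note shows. Statements on the series, on what has been measured and on what is new or still open speak of the compounds shown alone.

The measured compounds: compound 1 `O=C1c2ccccc2N(Cc2ccccc2Cl)S(=O)(=O)N1COCc1ccccc1`, compound 2 `O=C1c2ccccc2N(Cc2ccccc2)S(=O)(=O)N1COCc1ccccc1`, compound 3 `O=C1c2ccccc2N(Cc2ccc(Cl)cc2)S(=O)(=O)N1Cc1ccc(Cl)cc1`.

In a functional assay on HEL cells (Homo sapiens) (a lower number here means that less compound is tolerated, a higher number that more compound is tolerated), compound 1 gives 200000 nM and compound 2 gives 49000 nM. Compound 3 is recorded only as a limit of this assay, > 50000 nM, and sits at the limit of > 50000 nM in this assay, at which 1 of the 3 values shown sits.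

The change from compound 1 to compound 2, (hydrogen in place of chloro on an aromatic carbon), produced a 4.1-fold lower number from compound 1 to compound 2 (0.61 log units; beyond the scatter). How the core of compound 3 differs from that of compound 1 is not broken down here. Compound 4 `O=C1c2ccccc2N(Cc2ccc(Cl)cc2)S(=O)(=O)N1Cc1ccccc1` arises from compound 3 by hydrogen in place of chloro on an aromatic carbon; here the leaving chloro sits para to a large group, whereas in compound 1 it sat ortho to a large group, so this is the same kind of change, not the same one.

Compound 4 is therefore expected to show an at least 1.2-fold lower number from compound 3 to compound 4 (0.09 log units; that floor lies within the scatter), an expectation that rests on a 4.1-fold lower number from compound 1 to compound 2 (0.61 log units; beyond the scatter) and on compound 3 being recorded only as a limit. Compound 4 is estimated at about 40000 nM, most likely between 12000 nM and 150000 nM.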

Compound 4, minimum cytotoxic concentration: > 5000 nM
Compound 4 gave a limit, no number (the forecaster's own chance of this, stated with the estimate: 40%); the middle value lies beyond the limit too.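

Compound 3 and compound 4 are both recorded only as limits in this assay, so the step between them cannot be read. The compounds shown leave open whether hydrogen in place of chloro changes the tolerated concentration here, as it did from compound 1 to compound 2.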